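Benzoxaborole propanamides: cyclohexyl to iodophenyl on the amide nitrogen

The compounds below may be only part of what the source reports. "The series", "measured", "known", "first", "only" and "open" are said of these compounds alone.

Measured so far:
compound 1 `O=C(CCc1cccc2c1B(O)OC2)NC1CCCCC1` — > 100000 nM
compound 2 `COc1ccc(NC(=O)CCc2cccc3c2B(O)OC3)cc1` — 850 nM
compound 3 `CCOC(=O)c1ccc(NC(=O)CCc2cccc3c2B(O)OC3)cc1` — > 100000 nM

The shared core carries a propanamide whose nitrogen bears the varied group. In a functional assay on MDA-MB-231 cells (Homo sapiens) for antiproliferative activity, read by MTT assay, with a stated time of 72 h (a lower number here means a stronger inhibitor, a higher number a weaker inhibitor), compound 1 returns only a limit, > 100000 nM, so its true number is not known. Compound 2, with a methoxyphenyl group, gives 850 nM. Compound 3 returns only a limit, > 100000 nM. Within the data shown here, the one measured step, an at least 110-fold higher number from compound 2 to compound 3 (2.07 log units; beyond the scatter), shows that exchanging one aryl substituent for another can move the result from a clear number to the limit (the limit of > 100000 nM in this assay, at which 2 of the 3 values shown sit).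

Compound 4 `O=C(CCc1cccc2c1B(O)OC2)Nc1cccc(I)c1` is the next candidate. Relative to compound 1 the change is 3-iodophenyl in place of cyclohexyl on an amide-type nitrogen. Among the measured compounds shown here, no measured step exchanges an aliphatic group for an aromatic one, so nothing bears directly on this step. What is known is that one aryl amide, compound 2, gives 850 nM. Another aryl amide, compound 3, returns only a limit. On that basis compound 4 is expected to land at a measurable value rather than at the limit, though the spread must stay wide. The estimate for compound 4 in this assay is 3000 nM, between 400 nM and 100000 nM, which would mean an expected step of an at least 33-fold lower number from compound 1 to compound 4 (1.52 log units; beyond the scatter).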

Compound 4, half-maximal inhibitory concentration: 5300 nM
Beside the measured number, compound 4's estimate is 1.8-fold (0.25 log units) below it; the range from low to high includes it.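

In this assay, among these compounds, the exchange of cyclohexyl for 3-iodophenyl on the amide-type nitrogen gives an at least 18-fold lower number from compound 1 to compound 4 (1.27 log units; beyond the scatter), the only measured step here from an aliphatic ring to an aromatic one. From the compounds shown here alone, the true size of that step stays open, since compound 1 supplies only a limit at one end of it: the limit of > 100000 nM in this assay, at which 2 of the 4 values shown sit. Compound 4 joins compound 2 as a second aryl amide with a clear number, so a measurable result at this position does not depend on the methoxy group alone, but compound 3 goes against any rule that an aryl amide is enough, and its result remains a limit, > 100000 nM.

A plain phenyl group on the amide-type nitrogen would separate the part played by the aromatic ring from that of the iodine, which the compounds shown cannot do. Equally open, going by these compounds, is how a bromine or chlorine in place of the iodine of compound 4, or a carboxylic acid in place of the ethoxycarbonyl group of compound 3, would read in this assay.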